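A few compounds are considered here, and "the series" means these few. Any claim that something is new, unique, unknown or untested is made for them only; others in the source may bear on it.

Measured so far:
compound 1, `CC(C)(C)OC(=O)N1CCC(Oc2cccc3c2CCN3c2ccc(S(C)(=O)=O)cc2)CC1`, 92%
compound 2, `CC(C)OC(=O)N1CCC(Oc2cccc3c2CCN3c2ccc(S(C)(=O)=O)cc2F)CC1`, 62%
compound 3, `CC(C)(C)COC(=O)N1CCC(Oc2ncnc3c2CCN3c2ccc(S(C)(=O)=O)cc2F)CC1`, 80%

All three numbers come from a functional assay on CHO-K1 cells with Glucose-dependent insulinotropic receptor (Homo sapiens) as the target, read by a luciferase reporter, with a stated time of 5 h; on this read-out higher numbers stand for larger maximal responses and lower numbers for smaller maximal responses. Within this set compound 3 stands second highest of three: its nearest neighbour is compound 1, whose number lies higher by a gap beyond the scatter, and its furthest is compound 2, whose number lies lower by a gap also beyond the scatter. No single-point comparison between any two of the measured compounds exists, so the three values are taken as they stand and nothing is read from them about the carbamate or the core.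

The next compound in the series is compound 4, `CS(=O)(=O)c1ccc(N2CCc3c(OC4CCN(C5=NCCCN5)CC4)ncnc32)c(F)c1`. Set against compound 3 the change is a group of 6 heavy atoms (4 carbon, 2 nitrogen; one six-membered non-aromatic ring with 2 hetero atoms) in place of a group of 8 heavy atoms (6 carbon, 2 oxygen; no ring), on an amine nitrogen in a ring. No measured pair shows a change of this kind, so the size of the step in this assay cannot be anchored to a shown step. The expectation is a downward step of moderate size, beyond the scatter, since the group that leaves is the one present in every measured compound and the entering ring is new to the set.

For compound 4 the expected value in this assay is 68%, with a range from 40% to 92%. This expected step, a number 12 percentage points lower from compound 3 to compound 4 (beyond the scatter), is an estimate, not a measured result.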

Compound 4, largest response reached (reported as percent of maximum), in percent of the reference or control that the assay uses: 66%
Compound 4: the middle estimate sits 2 percentage points above what was measured, within the range that was stated.
By their numbers in this assay, from the lowest: compounds 2 and 4 (each within the scatter of the next); then compound 3; then compound 1.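

In this assay, this position now has its first readable step: a number 14 percentage points lower from compound 3 to compound 4 (beyond the scatter), with the ring of 6 heavy atoms replacing neopentyloxycarbonyl on the amine nitrogen in a ring. Going by these compounds alone, the carbamate shared by the earlier compounds is therefore not required for a measurable maximal response, since compound 4 lacks it and still gives 66%, although the step is beyond the scatter and the change does cost part of the response of compound 3. No measurement shown here accounts for the direction or size of this step.

As this single step swaps the whole group, it does not separate the effect of removing the neopentyloxycarbonyl from that of introducing the new ring, so neither can be credited with the lower number on its own. Open questions are where an open-chain guanidine, a urea or a five-membered cyclic amidine on the same nitrogen would fall relative to compound 3 and compound 4, and whether the same exchange would give a step of similar size on the core of compound 1.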